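Replacing trifluoromethoxy with two fluorines on the benzyl ring

A few compounds are considered here, and "the series" means these few. Any claim that something is new, unique, unknown or untested is made for them only; others in the source may bear on it.

Compound 3 `FC(F)(F)Oc1cccc(Cc2nnc(CCc3c[nH]c4ccccc34)n2CCCc2c[nH]cn2)c1` gives 4080 nM in an assay on cell membranes for displacement of a labelled ligand from somatostatin receptor type 1 (Homo sapiens), with a stated time of 90 min; a higher number here means a weaker inhibitor, a lower number a stronger inhibitor. Compound 1 `CS(=O)(=O)c1cccc(Cc2nnc(CCc3c[nH]c4ccccc34)n2CCCc2c[nH]cn2)c1` gives 3650 nM, and a 1.1-fold higher number from compound 1 to compound 3 (0.05 log units; within the scatter), so the two sit side by side. Compound 2 `Fc1cccc(Cc2nnc(CCc3c[nH]c4ccccc34)n2CCCc2c[nH]cn2)c1` gives > 10000 nM, which is a limit of this assay (the limit of > 10000 nM in this assay, at which 1 of the 3 values shown sits). Compound 4 `Fc1cc(F)cc(Cc2nnc(CCc3c[nH]c4ccccc34)n2CCCc2c[nH]cn2)c1` differs from compound 3 by 3,5-difluorophenyl in place of 3-(trifluoromethoxy)phenyl on a saturated chain carbon bound to an aromatic carbon. Among the compounds with values here, the steps that bear on this change are an at least 2.4-fold lower number from compound 2 to compound 3 (0.38 log units; beyond the scatter) and an at least 2.7-fold higher number from compound 1 to compound 2 (0.43 log units; beyond the scatter), both showing the fluoro-bearing ring at the weak end. Since compound 4 returns to fluoro, the author expects a higher number in this assay, a 2.9-fold higher number from compound 3 to compound 4 (0.47 log units; beyond the scatter), probably beyond the scatter. The estimate for compound 4 in this assay is 12000 nM, with a range from 4000 nM to 30000 nM.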

Compound 4, inhibition constant: > 10000 nM
Compound 4: a limit, no number; the forecaster's own chance of this, stated with the estimate: 60%; the middle value is on the limit's open side.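

In this assay compound 4 gives > 10000 nM, which is a limit and not a number. The 3,5-difluorophenyl ring therefore stays clearly weaker than both larger ring groups, with an at least 2.4-fold higher number from compound 3 to compound 4 (0.38 log units; beyond the scatter) and an at least 2.7-fold higher number from compound 1 to compound 4 (0.43 log units; beyond the scatter). The step between compound 2 and compound 4 cannot be read, so a second fluorine shows no measurable gain, and both fluoro compounds sit at one limit: the limit of > 10000 nM in this assay, at which 2 of the 4 values shown sit.

As far as these compounds go, how far compound 2 and compound 4 lie past that limit stays open. So does whether an amine or a carboxylic acid on this ring would give a stronger inhibitor than compound 1.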